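The source may report more compounds than this note shows. Statements on the series, on what has been measured and on what is new or still open speak of the compounds shown alone.

Measured so far:

Compound 1, `O=[N+]([O-])c1ccc2nc(CNc3ccccc3)cnc2c1` — in a functional assay on MCF7 cells (Homo sapiens) for cytotoxicity, read by MTT assay, with a stated time of 96 h (a lower number here means a stronger inhibitor, a higher number a weaker inhibitor), compound 1 gives 61000 nM.
Compound 2, `Cc1ccc(NCc2cnc3cc([N+](=O)[O-])ccc3n2)cc1` — in this assay compound 2 gives 68000 nM.

On the numbers shown compound 2 stands together with compound 1, the only other measured compound: a 1.1-fold higher number from compound 1 to compound 2 (0.05 log units; within the scatter). The two cannot be told apart, so compound 2 has no position of its own yet.

Compound 3, `Cc1cccc(NCc2cnc3cc([N+](=O)[O-])ccc3n2)c1`, is the next compound. It differs from compound 2 as follows: 3-methylphenyl in place of 4-methylphenyl on an amine nitrogen. The methyl stays on the ring bound to the amine nitrogen; only its place on that ring moves.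

Among the measured compounds shown here, the single measured step, a 1.1-fold higher number from compound 1 to compound 2 (0.05 log units; within the scatter), bears on this only loosely: it put a methyl onto the ring in the first place and stayed within the scatter. For the measured compounds named here, no measured step moves a methyl from one ring position to another, so there is nothing that points to a direction. The expectation in this assay is therefore a step within the scatter, a 1.0-fold lower number from compound 2 to compound 3 (0.02 log units; within the scatter), with the range kept wide for the lack of a matched step. Compound 3 is estimated at 65000 nM, between 30000 nM and 140000 nM.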

Compound 3, half-maximal inhibitory concentration: 79000 nM
Beside the measured number, compound 3's estimate is 1.2-fold (0.08 log units) below it; measured number inside the range.
By their numbers in this assay, from the lowest: compounds 1, 2 and 3 (each within the scatter of the next).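

In this assay the move of the methyl on the ring bound to the amine nitrogen gives a 1.2-fold higher number from compound 2 to compound 3 (0.07 log units; within the scatter) and so 3-methylphenyl and 4-methylphenyl cannot be told apart at this place. The second methyl placement also leaves the comparison with the compound lacking a methyl unresolved, with a 1.3-fold higher number from compound 1 to compound 3 (0.11 log units; within the scatter) as the result, so neither methyl placement shown separates from the hydrogen of compound 1 and the three compounds form one group with no order among them. Nothing at hand explains why this ring tolerates these changes without a measurable difference.

The compounds shown leave open whether any group on this ring can separate from hydrogen at all, since methyl is the only group shown here, and a chlorine, a methoxy group or a carboxylic acid at either ring place might behave differently. Also open, as far as these compounds go, is what the amine nitrogen and the nitro group of the shared core contribute, for example with an amide in place of that amine or with an amine in place of the nitro group.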